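Repositioning two fluorines on the benzyl arm and cytotoxicity

This account rests on a few compounds, and the source may have more. Where it says the series, first, only, none or still open, it means among the compounds named here.

Measured compounds:
compound 1 `CCOC(=O)/C(O)=C/C(=O)c1cn(Cc2cccc(F)c2)c2cccc(OC)c12` 63200 nM
compound 2 `CCOC(=O)/C(O)=C/C(=O)c1cn(Cc2ccccc2F)c2cccc(OC)c12` 63300 nM
compound 3 `CCOC(=O)/C(O)=C/C(=O)c1cn(Cc2cccc(F)c2F)c2cccc(OC)c12` 21100 nM

In an ADME assay on MT4 cells (Homo sapiens) for cytotoxicity, read by MTT assay (a lower number here means that less compound is tolerated, a higher number that more compound is tolerated), compound 3 gives the lowest number of the three. It sits a 3.0-fold lower number from compound 1 to compound 3 (0.48 log units; beyond the scatter) and a 3.0-fold lower number from compound 2 to compound 3 (0.48 log units; beyond the scatter), both steps adding a single fluoro to a benzyl ring that already carries one. Between the two monofluoro compounds the move of the fluoro around the ring, a 1.0-fold higher number from compound 1 to compound 2 (0.00 log units; within the scatter), is within the scatter.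

Compound 4 `CCOC(=O)/C(O)=C/C(=O)c1cn(Cc2cc(F)cc(F)c2)c2cccc(OC)c12` differs from compound 3 by 3,5-difluorophenyl in place of 2,3-difluorophenyl on a saturated chain carbon bound to an aromatic nitrogen. The fluorine count is unchanged; only their placement moves. Among the measured compounds shown here, the one comparable positional swap, a 1.0-fold higher number from compound 1 to compound 2 (0.00 log units; within the scatter), gave no shift beyond the scatter, while the second fluoro in compound 3 produced the modest lowering seen in a 3.0-fold lower number from compound 2 to compound 3 (0.48 log units; beyond the scatter). Compound 4 is therefore expected to stay close to compound 3, with a step of a 1.3-fold higher number from compound 3 to compound 4 (0.12 log units; within the scatter) that may not exceed the scatter. The estimate for compound 4 in this assay is 28000 nM, with a range from 12000 nM to 70000 nM.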

Compound 4, half-maximal cytotoxic concentration: 34700 nM
Compound 4: the middle estimate sits 1.2-fold (0.09 log units) below what was measured; the measured number falls inside the stated range.
By their numbers in this assay, from the lowest: compounds 3, 4, 1 and 2 (each within the scatter of the next, the first and the last beyond it).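

Moving both fluorines, from 2,3-difluorobenzyl to 3,5-difluorobenzyl, gives a 1.6-fold higher number from compound 3 to compound 4 (0.22 log units; within the scatter), so placement on this arm makes no readable difference among the difluoro compounds, just as it made none between the monofluoro compounds. Adding a second fluoro does not always pass the scatter either, as a 1.8-fold lower number from compound 2 to compound 4 (0.26 log units; within the scatter) and a 1.8-fold lower number from compound 1 to compound 4 (0.26 log units; within the scatter) both stay within it, which leaves compound 3 as the only difluoro compound with steps beyond it. Even so, the two additions cannot be said to differ from each other: the same change on two cores in this assay, a 3.0-fold lower number (0.48 log units; beyond the scatter) from compound 2 to compound 3 and a 1.8-fold lower number (0.26 log units; within the scatter) from compound 1 to compound 4, 1.6-fold (0.22 log units) apart, within the scatter of two such steps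

On these data alone, what a chloro, a trifluoromethyl or an amine on the benzyl ring would do in this assay stays open. So does the effect of a longer chain in place of the benzyl carbon that joins this ring to the aromatic nitrogen.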